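Methyl on the Ring Nitrogen: From Compound 1 to Compound 4

The compounds below may be only part of what the source reports. "The series", "measured", "known", "first", "only" and "open" are said of these compounds alone.

Compound 1 `CC(=O)N1CCN(c2ccc(Nc3nccc(-c4c[nH]c5cccnc45)n3)cc2)CC1`: 420 nM
Compound 2 `CC(=O)N1CCN(c2ccc(Nc3ncc(C#N)c(-c4cn(C)c5ccccc45)n3)cc2)CC1`: 30 nM
Compound 3 `CN1CCN(c2cccc(Nc3nccc(-c4c[nH]c5cccnc45)n3)c2)CC1`: 405 nM

In a functional assay on MV4-11 cells (Homo sapiens) for antiproliferative activity, read by resazurin assay, with a stated time of 72 h (a higher number here means a weaker inhibitor of growth, a lower number a stronger inhibitor of growth), compound 1 gives 420 nM, the highest of the three numbers, though compound 3 at 405 nM lies within the usual scatter of it. Compound 2 gives 30 nM, a gap beyond the scatter.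

Compound 4 `CC(=O)N1CCN(c2ccc(Nc3nccc(-c4cn(C)c5ncccc45)n3)cc2)CC1` differs from compound 1 in one place: a group of 10 heavy atoms (8 carbon, 2 nitrogen; one five-membered aromatic ring with 1 hetero atom, one six-membered aromatic ring with 1 hetero atom) in place of a group of 9 heavy atoms (7 carbon, 2 nitrogen; one five-membered aromatic ring with 1 hetero atom, one six-membered aromatic ring with 1 hetero atom), on an aromatic carbon. Within the data shown here, no measured pair shares this change, so its size is not fixed by the data. Compound 2, whose corresponding group likewise has no hydrogen-bond donor, shows at 30 nM that such a group is compatible with a low number. The step from compound 1 to compound 4 is expected to be small, a 1.1-fold lower number from compound 1 to compound 4 (0.02 log units; within the scatter), not clearly beyond the scatter in either direction. Compound 4 is estimated at 400 nM, within 100 nM to 1600 nM.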

Compound 4, concentration for 50% growth inhibition: 74 nM
The estimate for compound 4 lay 5.4-fold (0.73 log units) above the measured number, outside the stated range (below it).
By their numbers in this assay, from the lowest: compound 2; then compound 4; then compounds 3 and 1 (each within the scatter of the next).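

In this assay, the change of group on this aromatic carbon gives a 5.7-fold lower number from compound 1 to compound 4 (0.75 log units; beyond the scatter). So at this position, the group with 1 hydrogen-bond donor is not needed for a low number: the entering group has 0 hydrogen-bond donors and does better. Nothing available explains why the number falls. On these data alone, whether an ethyl group or a longer chain in place of the methyl would lower the number further remains open. So does whether the same change would give a similar step on compound 3.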